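Amine variation on the shared core: outlook for compound 4

The source may hold more compounds than are shown below. What is called first, only, known or untested is meant among the compounds shown, and "the series" means these compounds.

Compound 3 `CCC1CCCCN1c1nc(C)nc2c(-c3c(C)cc(OC)cc3OC)c(C)nn12` gives 3.26 nM in an assay on cell membranes for displacement of a labelled ligand from corticotropin-releasing factor receptor 1 (Rattus norvegicus); a lower number here means a stronger inhibitor, a higher number a weaker inhibitor. Compound 2 `CCN(CCC#N)c1nc(C)nc2c(-c3c(C)cc(OC)cc3OC)c(C)nn12` gives 2.48 nM and compound 1 `CCCN(C)c1nc(C)nc2c(-c3c(C)cc(OC)cc3OC)c(C)nn12` gives 6.48 nM; the steps of a 2.0-fold lower number from compound 1 to compound 3 (0.30 log units; within the scatter) and a 1.3-fold higher number from compound 2 to compound 3 (0.12 log units; within the scatter) both stay within the scatter, so compound 3 is not separated from either neighbour, and only a 2.6-fold lower number from compound 1 to compound 2 (0.42 log units; beyond the scatter) reaches beyond the scatter. Compound 4 `CCN(CC)c1nc(C)nc2c(-c3c(C)cc(OC)cc3OC)c(C)nn12` carries diethylamino in place of 2-ethylpiperidin-1-yl on an aromatic carbon. Among the measured compounds shown here, no measured step introduces diethylamino; the two steps that concern the leaving 2-ethylpiperidin-1-yl, a 2.0-fold lower number from compound 1 to compound 3 (0.30 log units; within the scatter) and a 1.3-fold higher number from compound 2 to compound 3 (0.12 log units; within the scatter), were small, and compound 1, which also carries an amine without a ring, gave 6.48 nM. Little movement beyond the scatter is therefore expected in this assay; the estimated step is a 1.5-fold higher number from compound 3 to compound 4 (0.19 log units; within the scatter). Compound 4 is expected at 5 nM, between 2 nM and 13 nM.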

Compound 4, half-maximal inhibitory concentration: 1.2 nM
Beside the measured number, compound 4's estimate is 4.2-fold (0.62 log units) above it; measured number outside the range, below it.
By their numbers in this assay, from the lowest: compound 4; then compounds 2, 3 and 1 (each within the scatter of the next, the first and the last beyond it).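

Among the compounds shown here, at the aromatic carbon between two ring nitrogen atoms, diethylamino is the first amine separated beyond the scatter from all the others in this assay (a 2.7-fold lower number from compound 3 to compound 4 (0.43 log units; beyond the scatter)) and (a 5.4-fold lower number from compound 1 to compound 4 (0.73 log units; beyond the scatter)). Removing the nitrile from the chain of compound 2 also counts here (a 2.1-fold lower number from compound 2 to compound 4 (0.32 log units; beyond the scatter)), so compound 4 is the strongest inhibitor of the four. Lacking a ring does not decide the matter, as compound 1 also carries an amine without a ring.

On these data alone, how dipropylamino or bis(2-methoxyethyl)amino would read at this position remains open. Nothing at hand explains why diethylamino gives the lowest number.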